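The source may report more compounds than this note shows. Statements on the series, on what has been measured and on what is new or still open speak of the compounds shown alone.

Compound 1 `CC(C)=CCC/C(C)=C/CC/C(C)=C/CC[C@@H]1[C@@]2(C)CC/C(=N\OCc3cn(-c4c(Cl)cc([N+](=O)[O-])cc4Cl)nn3)C(C)(C)[C@@H]2CC[C@@]1(C)O` and compound 2 `COc1cc(OC)c(-n2cc(CO/N=C3\CC[C@]4(C)[C@@H](CC/C=C(\C)CC/C=C(\C)CCC=C(C)C)[C@](C)(O)CC[C@H]4C3(C)C)nn2)c(OC)c1` share one core and differ at a single spot: 2,4,6-trimethoxyphenyl in place of 2,6-dichloro-4-nitrophenyl on an aromatic nitrogen. In a functional assay on HepG2 cells (Homo sapiens) for cytotoxicity, read by MTT assay, with a stated time of 48 h (a higher number here means a weaker inhibitor, a lower number a stronger inhibitor), compound 1 gives 34900 nM, and compound 2 gives 14100 nM. Moving from one to the other produces a 2.5-fold lower number from compound 1 to compound 2 (0.39 log units; beyond the scatter).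

Compound 3 `CC(C)=CCC/C(C)=C/CC/C(C)=C/CC[C@@H]1[C@@]2(C)C/C(=C\c3ccc(OCc4cn(-c5c(Cl)cc([N+](=O)[O-])cc5Cl)nn4)cc3)C(=O)C(C)(C)[C@@H]2CC[C@@]1(C)O` carries the same 2,6-dichloro-4-nitrophenyl group, but on a different core; how the core of compound 3 differs from the core of compound 1 is not broken down here. In this assay compound 3 gives 25100 nM, a number that lies within the usual scatter of both compound 1 and compound 2.

Compound 4 `COc1cc(OC)c(-n2cc(COc3ccc(/C=C4\C[C@]5(C)[C@@H](CC/C=C(\C)CC/C=C(\C)CCC=C(C)C)[C@](C)(O)CC[C@H]5C(C)(C)C4=O)cc3)nn2)c(OC)c1` is built from compound 3 by the same change: 2,4,6-trimethoxyphenyl in place of 2,6-dichloro-4-nitrophenyl on an aromatic nitrogen. The surroundings of the change match word for word, so this is the same change, not merely a similar one. The step into compound 4 in this assay is expected to be a 2.3-fold lower number from compound 3 to compound 4 (0.36 log units; beyond the scatter), resting on a 2.5-fold lower number from compound 1 to compound 2 (0.39 log units; beyond the scatter) together with the starting value of compound 3. Compound 4 is therefore estimated at 11000 nM, with a likely range from 5000 nM to 25000 nM.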

Compound 4, half-maximal inhibitory concentration: 57500 nM
The estimate for compound 4 lay 5.2-fold (0.72 log units) below the measured number; measured number above the stated range.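

In this assay, putting 2,4,6-trimethoxyphenyl in place of 2,6-dichloro-4-nitrophenyl gave a 2.3-fold higher number from compound 3 to compound 4 (0.36 log units; beyond the scatter), so on this core the number moved in the opposite direction from the one seen on the core of compound 1. The change therefore did not carry over from one core to the other, and the two cores responded differently: the same change on two cores in this assay, a 2.5-fold lower number (0.39 log units; beyond the scatter) from compound 1 to compound 2 and a 2.3-fold higher number (0.36 log units; beyond the scatter) from compound 3 to compound 4, 5.7-fold (0.75 log units) apart, beyond the scatter of two such steps. Within the data shown here, with only two pairs, this shows that the step on one core failed to predict the step on the other, but it does not explain the difference or show how the change would behave on any further core.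

The compounds shown leave open whether the reversal comes from the aryl group as a whole or from one part of it, as the nitro, chloro and methoxy groups always change together here. An unsubstituted phenyl group, or a phenyl group carrying a single methoxy group, made on both cores would help separate these parts.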